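Pyrazole urea series: urea to benzamide at the aryl end

The compounds below may be only part of what the source reports. "The series", "measured", "known", "first", "only" and "open" are said of these compounds alone.

Measured so far in a functional assay on OVCAR-8 cells (Homo sapiens) for inhibition, read by sulforhodamine B assay, with a stated time of 48 h; a higher number here means that more compound is tolerated, a lower number that less compound is tolerated:
compound 1 `COc1cc(-c2nn(-c3cccc(NC(=O)Nc4ccc(Cl)c(Cl)c4)c3)cc2-c2ccncc2)ccc1Cl`, limit > 50000 nM
compound 2 `O=C(Nc1cccc(-n2cc(-c3ccncc3)c(-c3ccc(Cl)c(O)c3)n2)c1)Nc1ccc(Cl)c(Cl)c1`, limit > 32500 nM
compound 3 `O=C(Nc1cccc(-n2cc(-c3ccncc3)c(-c3ccc(Cl)c(O)c3)n2)c1)Nc1cc(C(F)(F)F)cc(C(F)(F)F)c1`, 43700 nM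

Compound 1 stands at a limit of this assay and not at a number. Compound 2 likewise stands at a limit. Compound 3 gives a number, and it lies in the same high region as the two limits. Between compound 1 and compound 2 the only step that can be read is a step that the two limits leave unreadable from compound 1 to compound 2, and its size is unreadable because the limit of > 32500 nM in this assay, at which 1 of the 3 values shown sits, and the limit of > 50000 nM in this assay, at which 1 of the 3 values shown sits, bound both ends. Among the measured compounds shown here, no step bears on the amide end of the molecule, as compound 2 and compound 3 differ only in the second aryl ring of the urea and both stay in the high region.

Compound 4 `COc1cc(-c2nn(-c3cccc(NC(=O)c4ccccc4)c3)cc2-c2ccncc2)ccc1Cl` is the unmeasured compound; its change from compound 1 is phenyl in place of (3,4-dichlorophenyl)amino on a carbonyl carbon. For the measured compounds named here, with no measured step at this position, and all three known values at or near the top of this assay, the expected step of a number no higher from compound 1 to compound 4 (the limit leaves the size open) is none beyond the scatter. Compound 4 is therefore expected to give 50000 nM, with a range from 20000 nM to 100000 nM, and a limit rather than a number is the more likely outcome.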

Compound 4, concentration lethal to 50% of the cells: > 100000 nM
Compound 4: no number, only a limit (the forecaster's own chance of this, stated with the estimate: 65%); at least 2.0-fold (0.30 log units) between middle value and limit.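

In this assay compound 4 gives > 100000 nM, which is a limit. Compound 1 also stands at a limit, and no step can be read from compound 1 to compound 4. The compounds shown leave open whether phenyl in place of (3,4-dichlorophenyl)amino on a carbonyl carbon changes the read-out at all.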